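Moving one fluorine on the benzyl group

The source may report more compounds than this note shows. Statements on the series, on what has been measured and on what is new or still open speak of the compounds shown alone.

Values in a functional assay on SW 1116 cells (Homo sapiens) for antiproliferative activity, read by MTT assay, with a stated time of 24 h; on this read-out lower numbers stand for stronger inhibition and higher numbers for weaker inhibition:
Compound 1 `Clc1cccc(CSc2nnc(-c3ccc4c(c3)OCCO4)n2-c2ccccc2)c1` gives 10600 nM
Compound 2 `Cc1ccc(CSc2nnc(-c3ccc4c(c3)OCCO4)n2-c2ccccc2)cc1` gives 16200 nM
Compound 3 `Fc1ccccc1CSc1nnc(-c2ccc3c(c2)OCCO3)n1-c1ccccc1` gives 13600 nM

These three compounds share a core and differ only in the aromatic group on a saturated chain carbon bound to a sulfur. Their values cannot be ranked, as every step between them lies within the usual scatter: a 1.5-fold higher number from compound 1 to compound 2 (0.18 log units; within the scatter), a 1.3-fold higher number from compound 1 to compound 3 (0.11 log units; within the scatter) and a 1.2-fold lower number from compound 2 to compound 3 (0.08 log units; within the scatter). Compound 3, at 13600 nM, therefore stands inside this tight group rather than apart from it.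

Compound 4 `Fc1ccc(CSc2nnc(-c3ccc4c(c3)OCCO4)n2-c2ccccc2)cc1` has 4-fluorophenyl in place of 2-fluorophenyl at that same place (4-fluorophenyl in place of 2-fluorophenyl on a saturated chain carbon bound to a sulfur). This exact swap has not been measured, so the closest evidence is the set of group changes at this place, above all a 1.2-fold lower number from compound 2 to compound 3 (0.08 log units; within the scatter) and a 1.3-fold higher number from compound 1 to compound 3 (0.11 log units; within the scatter). Neither moved the number beyond the scatter, and three compounds are a small sample, so no step beyond the scatter is expected in this assay. The estimated change is a 1.0-fold lower number from compound 3 to compound 4 (0.02 log units; within the scatter). For compound 4 the expected value is 13000 nM, with an estimated range from 6500 nM to 24000 nM.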

Compound 4, half-maximal inhibitory concentration: 20800 nM
Compound 4: middle estimate off by 1.6-fold (0.20 log units), on the low side; the measured number falls inside the stated range.
By their numbers in this assay, from the lowest: compounds 1, 3, 2 and 4 (each within the scatter of the next).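

In this assay moving the one fluorine from 2-fluorophenyl to 4-fluorophenyl, which keeps the same atoms joined differently, gives a 1.5-fold higher number from compound 3 to compound 4 (0.18 log units; within the scatter) and so does not separate the two compounds; among these four, where the fluorine sits on the ring makes no readable difference. Compound 4 also stays within the scatter of the two other groups at this place on a saturated chain carbon bound to a sulfur, with a 1.3-fold higher number from compound 2 to compound 4 (0.11 log units; within the scatter) and a 2.0-fold higher number from compound 1 to compound 4 (0.29 log units; within the scatter) as its steps, so even this largest step in the set leaves all four compounds as one group that cannot be ranked. Nothing measured here offers an explanation for the spread of these numbers.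

As far as these compounds go, all four compounds carry a simple substituted phenyl ring at this place, so it remains open whether an amine or a carboxylic acid on that ring, or a longer chain in place of the benzyl group, would shift the number beyond the scatter in this assay at all. The shared core also stays the same throughout, which leaves open how much any other part of the molecule contributes.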